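Swapping the fused ring group for pyrimidin-4-yl

The source may hold more compounds than are shown below. What is called first, only, known or untested is meant among the compounds shown, and "the series" means these compounds.

Values in a physicochemical assay for solubility, measured as kinetic solubility (a lower number here means a less soluble compound, a higher number a more soluble compound), for the measured compounds:
- compound 1 `O=C(Nc1ccc(Cl)c(C(F)(F)F)c1)N[C@H]1CCN(c2ccc3nncn3n2)C1` gives 1000 nM
- compound 2 `CNc1nccc(N2CC[C@H](NC(=O)Nc3ccc(C)c(Cl)c3)C2)n1` gives 72700 nM
- compound 3 `O=C(Nc1ccc(Cl)c(C(F)(F)F)c1)N[C@@H]1CCN(c2ccc3nncn3n2)C1` gives 1000 nM

Compound 1 stands level with compound 3 on the lowest number of the three, while compound 2 has the highest. Compound 4 `O=C(Nc1ccc(Cl)c(C(F)(F)F)c1)N[C@H]1CCN(c2ccncn2)C1` changes one group of compound 1 on an amine nitrogen in a ring: a group of 6 heavy atoms (4 carbon, 2 nitrogen; one six-membered aromatic ring with 2 hetero atoms) in place of a group of 9 heavy atoms (5 carbon, 4 nitrogen; one five-membered aromatic ring with 3 hetero atoms, one six-membered aromatic ring with 2 hetero atoms), on an amine nitrogen in a ring and the group that enters is pyrimidin-4-yl. Among the measured compounds shown here, the one measured step between close relatives is no change at the digits printed from compound 1 to compound 3 (within the scatter) but it alters only configuration, so it offers no size for this swap. Compound 2 at 72700 nM shows only that much higher numbers occur among these compounds. A modest rise in this assay is therefore expected, an estimated 3.0-fold higher number from compound 1 to compound 4 (0.48 log units; beyond the scatter) for this swap. For compound 4 the estimate is 3000 nM with 1000 nM to 15000 nM as the expected range.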

Compound 4, solubility: 2400 nM
The estimate for compound 4 lay 1.3-fold (0.10 log units) above the measured number; low and high end bracket the measured number.
By their numbers in this assay, from the lowest: compounds 1 and 3 (each within the scatter of the next); then compound 4; then compound 2.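

Among the compounds shown here, compound 4 gives the first measured step at this position, the amine nitrogen in the ring. In this assay, replacing the larger two-ring group of compound 1 with pyrimidin-4-yl gives a 2.4-fold higher number from compound 1 to compound 4 (0.38 log units; beyond the scatter). So this group can be changed with a measurable shift in the number, whereas the earlier step altered only configuration, and nothing shown here explains the rise.

As far as these compounds go, it remains open whether an open-chain amine or a carboxylic acid at this position would shift the number further. It is also unknown whether pyrimidin-4-yl would give a similar step on compound 3.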